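Adding a methoxy group to a second member of the series

This account rests on a few compounds, and the source may have more. Where it says the series, first, only, none or still open, it means among the compounds named here.

Compound 1 `COc1ccc(CS(=O)(=O)/C=C/c2c(OC)cccc2OC)cc1[N+](=O)[O-]` and compound 2 `COc1ccc(CS(=O)(=O)/C=C/c2c(OC)cccc2OC)c([N+](=O)[O-])c1` are made of the same atoms joined differently; the difference between the two cores is not broken down here. In a functional assay on K562 cells (Homo sapiens) for cytotoxicity, read by trypan blue exclusion, with a stated time of 96 h (on this read-out lower numbers stand for stronger inhibition and higher numbers for weaker inhibition), compound 1 gives 20000 nM. In this assay compound 2 gives 50000 nM, the highest number of the three measured compounds, and its steps to both others are beyond the scatter. Compound 3 `COc1cc(OC)c(/C=C/S(=O)(=O)Cc2ccc(OC)c([N+](=O)[O-])c2)c(OC)c1` differs from compound 1 by one change: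

methoxy in place of hydrogen on an aromatic carbon

In this assay compound 3 gives 2500 nM, so that an 8.0-fold lower number from compound 1 to compound 3 (0.90 log units; beyond the scatter).

Compound 4 `COc1cc(OC)c(/C=C/S(=O)(=O)Cc2ccc(OC)cc2[N+](=O)[O-])c(OC)c1` carries the same change set on the core of compound 2:

methoxy in place of hydrogen on an aromatic carbon

Within the data shown here, the place of the change is described in the same words for both pairs, so it is taken as the same change, and only one measured example of it exists. Among the measured compounds shown here, compound 4 is expected to come in near 6000 nM, with a range from 2500 nM to 15000 nM allowed for the single supporting example. For the measured compounds named here, that estimate means a step of an 8.3-fold lower number from compound 2 to compound 4 (0.92 log units; beyond the scatter), set at roughly the size of the earlier step because an 8.0-fold lower number from compound 1 to compound 3 (0.90 log units; beyond the scatter) is the only guide to what this change does in this assay. From the compounds shown here alone, whether the change transfers from the core of compound 1 to the core of compound 2 is untested.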

Compound 4, half-maximal inhibitory concentration: 20000 nM
Beside the measured number, compound 4's estimate is 3.3-fold (0.52 log units) below it; measured number outside the range, above it.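

In this assay the methoxy in place of hydrogen on an aromatic carbon again moves the number down on the second core, with a 2.5-fold lower number from compound 2 to compound 4 (0.40 log units; beyond the scatter) and the direction of the earlier step therefore held on both cores. The size of the step, however, does not carry over from the core of compound 1 to the core of compound 2: the same change on two cores in this assay, an 8.0-fold lower number (0.90 log units; beyond the scatter) from compound 1 to compound 3 and a 2.5-fold lower number (0.40 log units; beyond the scatter) from compound 2 to compound 4, 3.2-fold (0.51 log units) apart, beyond the scatter of two such steps. These two pairs show that, in this series, the same change can differ in size between two cores made of the same atoms joined differently, but they give no general rule for other cores and do not show which feature of the cores sets the size of the step.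

From the compounds shown here alone, whether a hydroxy group, an amine, a carboxylic acid or a longer chain such as ethoxy, placed where this methoxy stands, would give a matching gap between the two cores remains open. Also open, going by these compounds, is whether the same gap would appear in a read-out other than this assay or in another cell line, as both pairs come from a single set of conditions.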